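The source may hold more compounds than are shown below. What is called first, only, known or untested is meant among the compounds shown, and "the series" means these compounds.

Working notes on the series. Of the compounds shown here, three of the shared core have so far been measured in an ADME assay for permeability, using PAMPA, with a stated time of 30 min, at pH 7.4; a higher number here means that the compound crosses the layer faster, a lower number that the compound crosses the layer more slowly. Compound 1 `COc1ccc(F)cc1CNCCCNc1ccnc2cc(Cc3ccc(C#N)cc3)ccc12` gives 23 10^-6 cm/s. Compound 2 `COc1ccc(F)cc1CNCCCNc1ccnc2cc(Oc3cccc(N(C)C)c3)ccc12` gives 317 10^-6 cm/s, and compound 3 `COc1ccc(F)cc1CNCCCNc1ccnc2cc(CCC(C)C)ccc12` gives 23 10^-6 cm/s. On these numbers compound 3 sits level with compound 1, the two together holding the lowest position, while compound 2 stands well apart: no change at the digits printed from compound 1 to compound 3 (within the scatter), a 14-fold lower number from compound 2 to compound 3 (1.14 log units; beyond the scatter), and a 14-fold higher number from compound 1 to compound 2 (1.14 log units; beyond the scatter).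

The next compound, compound 4 `COc1ccc(F)cc1CNCCCNc1ccnc2cc(CC3CCCCC3)ccc12`, differs from compound 3 in one place: cyclohexyl in place of isobutyl on a saturated chain carbon bound to an aromatic carbon. Going by the values given here, the only measured step at this place, where isobutyl replaced 4-cyanophenyl on a saturated chain carbon bound to an aromatic carbon, reads no change at the digits printed from compound 1 to compound 3 (within the scatter). The two large steps in the set both involve 3-(dimethylamino)phenoxy on an aromatic carbon and so do not bear on a change at the saturated chain carbon. Among the compounds with values here, the set holds no example of a ring entering at this position, so the expectation rests on a single step. For cyclohexyl in place of isobutyl at the same place, no step beyond the scatter is therefore expected in this assay; the expected step is a 1.1-fold higher number from compound 3 to compound 4 (0.04 log units; within the scatter). Compound 4 is expected to give 25 10^-6 cm/s, with a range from 12 10^-6 cm/s to 50 10^-6 cm/s.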

Compound 4, apparent permeability: 23 10^-6 cm/s
Beside the measured number, compound 4's estimate is 1.1-fold (0.04 log units) above it; the measured number falls inside the stated range.
By their numbers in this assay, from the lowest: compounds 1, 3 and 4 (each within the scatter of the next); then compound 2.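

Going by these compounds alone, at the saturated chain carbon bound to an aromatic carbon, a non-aromatic ring of carbon only now stands for the first time, and in this assay cyclohexyl in place of isobutyl gives no change at the digits printed from compound 3 to compound 4 (within the scatter), while cyclohexyl in place of 4-cyanophenyl gives no change at the digits printed from compound 1 to compound 4 (within the scatter). An open chain, an aromatic ring and a six-membered non-aromatic ring on this carbon thus read alike, and the ring with its 6 carbon atoms against the 4 of isobutyl leaves the number where it stood. Compound 2 remains apart, with cyclohexylmethyl in place of 3-(dimethylamino)phenoxy on an aromatic carbon giving a 14-fold lower number from compound 2 to compound 4 (1.14 log units; beyond the scatter), and no evidence is at hand that would explain any of these readings.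

The compounds shown do not separate the dimethylamino group from the ether oxygen in the large gap to compound 2, and an unsubstituted phenoxy group would be needed to part the two. Also open, on these data alone, is whether a piperidine ring, a morpholine ring or a carboxylic acid on the saturated chain carbon would read level with isobutyl, 4-cyanophenyl and cyclohexyl.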